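Exchanging the pendant aryl group on a shared core

The source may report more compounds than this note shows. Statements on the series, on what has been measured and on what is new or still open speak of the compounds shown alone.

Measured so far, in a functional assay on NCI-H460 cells (Homo sapiens) for cytotoxicity, read by MTT assay, with a stated time of 72 h; on this read-out higher numbers stand for weaker inhibition and lower numbers for stronger inhibition:
compound 1 `COc1ccc(-c2cc(C(=O)Nc3ccc(Oc4ccnc5cc(OCCCN6CCCCC6)c(OC)cc45)c(F)c3)c3ccccc3n2)cc1` gives 290 nM
compound 2 `COc1cccc(-c2cc(C(=O)Nc3ccc(Oc4ccnc5cc(OCCCN6CCCCC6)c(OC)cc45)c(F)c3)c3ccccc3n2)c1` gives 210 nM

Compound 2 holds the lower of the two numbers, but the step of a 1.4-fold lower number from compound 1 to compound 2 (0.14 log units; within the scatter) is within the scatter, so the two compounds are not distinguished by this assay. Compound 3 `COc1cc2c(Oc3ccc(NC(=O)c4cc(-c5ccc(F)cc5)nc5ccccc45)cc3F)ccnc2cc1OCCCN1CCCCC1` differs from compound 2 in one place: 4-fluorophenyl in place of 3-methoxyphenyl on an aromatic carbon. For the measured compounds named here, the only measured step that bears on this position is the one from compound 1 to compound 2, where moving the methoxy group around the pendant ring changed nothing beyond the scatter. Going by the values given here, replacing that ring with a 4-fluorophenyl is a different kind of change, and no measured pair shows what removing the methoxy group or adding a fluorine does here. With only a null step to go on, the expected step of a 1.2-fold higher number from compound 2 to compound 3 (0.08 log units; within the scatter) from compound 2 to compound 3 is none beyond the scatter, though the range is kept wide. Compound 3 is therefore estimated at 250 nM in this assay, between 90 nM and 700 nM.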

Compound 3, half-maximal inhibitory concentration: 21 nM
Compound 3: the middle estimate sits 12-fold (1.08 log units) above what was measured; the whole stated range lies above it.
By their numbers in this assay, from the lowest: compound 3; then compounds 2 and 1 (each within the scatter of the next).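

In this assay, this position on the shared core turns out to be able to shift the number well beyond the scatter: 4-fluorophenyl in place of 3-methoxyphenyl gives a 10-fold lower number from compound 2 to compound 3 (1.00 log units; beyond the scatter), and fluoro in place of methoxy gives a 14-fold lower number from compound 1 to compound 3 (1.14 log units; beyond the scatter). For the compounds shown here, the earlier pair showed only that moving the methoxy group around the pendant ring left the two compounds undistinguished, whereas exchanging that methoxy group for a fluoro on the ring separates compound 3 clearly from both methoxyphenyl compounds, so the result does not hang on which of them serves as the reference. Nothing measured here accounts for the size of this step, so it stands as an observation without an explanation.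

The compounds shown cannot say whether the step comes from losing the methoxy group or from gaining the fluorine, a question that an unsubstituted phenyl would address directly. They also leave open whether the placement of the fluorine on the ring matters, as a 3-fluorophenyl would show, and whether another halogen, as in a 4-chlorophenyl, or an amine on the ring would behave in the same way.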